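Ring Amide Replaces Chain Amide in Stilbene Series

The source may hold more compounds than are shown below. What is called first, only, known or untested is meant among the compounds shown, and "the series" means these compounds.

Compound 1 `COc1ccc(/C=C/c2cc(OC)cc(OC)c2/C=C/C(=O)N2CCCCC2)cc1` gives 6050 nM in a functional assay on MCF7 cells (Homo sapiens) for inhibition, read by MTT assay, with a stated time of 48 h; a higher number here means a weaker inhibitor, a lower number a stronger inhibitor. Compound 2 `COc1ccc(/C=C/c2cc(OC)cc(OC)c2/C=C/C(=O)NC(C)C)cc1` gives 2560 nM in this assay. Compound 3 `CCCCCCNC(=O)/C=C/c1c(/C=C/c2ccc(OC)cc2)cc(OC)cc1OC` gives 5530 nM in this assay.

Compound 3 sits with the second highest number of the three; it and compound 1 are indistinguishable, shown by a 1.1-fold lower number from compound 1 to compound 3 (0.04 log units; within the scatter), whereas a 2.2-fold higher number from compound 2 to compound 3 (0.33 log units; beyond the scatter) separates it from compound 2. Compound 4 `COc1ccc(/C=C/c2cc(OC)cc(OC)c2/C=C/C(=O)N2CCCC(C)C2)cc1` differs from compound 3 as 3-methylpiperidin-1-yl in place of hexylamino on a carbonyl carbon. The closest guide is a 1.1-fold lower number from compound 1 to compound 3 (0.04 log units; within the scatter): exchanging hexylamino for the plain piperidin-1-yl ring moved nothing beyond the scatter. Within the data shown here, no measured step shows the effect of the added methyl on that ring, so the expectation is a step of a 1.0-fold lower number from compound 3 to compound 4 (0.00 log units; within the scatter) that stays within the scatter. Compound 4 is therefore estimated at 5500 nM, ranging from 2500 nM to 12000 nM.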

Compound 4, half-maximal inhibitory concentration: 11900 nM
The estimate for compound 4 lay 2.2-fold (0.34 log units) below the measured number; measured number inside the range.
By their numbers in this assay, from the lowest: compound 2; then compounds 3, 1 and 4 (each within the scatter of the next, the first and the last beyond it).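

Placing the methyl on the ring of compound 1 (a 2.0-fold higher number from compound 1 to compound 4 (0.29 log units; within the scatter)) does not move the number in this assay beyond the scatter. Replacing hexylamino with 3-methylpiperidin-1-yl, which has the same heavy-atom count, does separate the two compounds (a 2.2-fold higher number from compound 3 to compound 4 (0.33 log units; beyond the scatter)), and replacing isopropylamino with it gives a larger separation (a 4.6-fold higher number from compound 2 to compound 4 (0.67 log units; beyond the scatter)). Nothing available explains these differences.

Going by these compounds, whether a morpholine or pyrrolidine amide would fall nearer compound 1 or compound 2 remains open. So does the effect of a cyclohexylamino group at this carbonyl carbon.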